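Mirroring One Stereocentre in Compound 2

This account rests on a few compounds, and the source may have more. Where it says the series, first, only, none or still open, it means among the compounds named here.

Two related compounds, compound 1 `CC(C(=O)SCCCCCCC(=O)Nc1nc(-c2ccccc2)cs1)c1ccccc1` and compound 2 `C[C@H](Cc1ccccc1)C(=O)SCCCCCCC(=O)Nc1nc(-c2ccccc2)cs1`, have been tested in a functional assay on MDA-MB-231 cells (Homo sapiens) for inhibition; on this read-out lower numbers stand for an effect already at smaller amounts and higher numbers for an effect only at larger amounts of compound. Compound 1 gives > 20000 nM; 27000 nM (2 entries). For compound 1, one of the several entries of compound 1 in this assay, > 20000 nM; 27000 nM (2 entries) is a limit of the assay rather than a number. Among the measured compounds shown here, compound 2 gives 3100 nM, the only single number available so far. The untested compound 3 `C[C@@H](Cc1ccccc1)C(=O)SCCCCCCC(=O)Nc1nc(-c2ccccc2)cs1` is built from the same pieces: the two compounds have the same atoms and bonds and differ only in configuration as drawn: 1 of 1 stereo elements differ; a stereocentre at a saturated chain carbon is drawn R in compound 2 and S in compound 3. For the measured compounds named here, no measured pair yet shows what such a change in configuration does in this assay, so the forecast stays anchored on compound 2 at 3100 nM. The expected change, a 1.5-fold higher number from compound 2 to compound 3 (0.16 log units; within the scatter), is modest and leans towards a weaker effect, although a result within the usual scatter would fit as well. For compound 3 the estimated value is 4500 nM, with an expected range from 1500 nM to 20000 nM.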

Compound 3, half-maximal effective concentration: 4000 nM
Estimate against measurement, compound 3: 1.1-fold (0.05 log units) above; the range from low to high includes it.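

In this assay, redrawing the stereocentre at a saturated chain carbon from R to S gives a 1.3-fold higher number from compound 2 to compound 3 (0.11 log units; within the scatter), so the two mirror forms cannot be told apart on this read-out. Among the compounds shown here, this pair gives the first direct reading of what configuration does here, and the reading is clean because nothing else separates the two compounds: the fact that compounds 2 and 3 differ only in the configuration as drawn. For the compounds shown here, it is still only one pair, at one stereocentre, so it says nothing yet about configuration elsewhere in such molecules.

On these data alone, it remains open whether the two mirror forms would stay this close if a different group, such as an amine or a carboxylic acid, were carried on the same chain carbon. A longer chain in the same place could also change the picture, and the compounds shown cannot settle either case.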